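The compounds below may be only part of what the source reports. "The series", "measured", "known", "first", "only" and "open" are said of these compounds alone.

In a functional assay on Ehrlich cells (Mus musculus) for cytotoxicity, read by trypan blue exclusion, with a stated time of 2 h (on this read-out lower numbers stand for stronger inhibition and higher numbers for weaker inhibition), compound 1 `CCCCNC(=S)NC1=C(C#N)C(c2ccc(Cl)cc2Cl)C2=C(CCCC2=O)N1c1ccc(S(N)(=O)=O)cc1` gives only a limit, > 100 ug/mL. In this assay compound 2 `N#CC1=C(NC(=S)Nc2ccccc2)N(c2ccc(S(N)(=O)=O)cc2)C2=C(C(=O)CCC2)C1c1ccc(Cl)cc1Cl` gives 25 ug/mL. In this assay compound 3 `N#CC1=C(NC(=S)Nc2ccc(Cl)cc2)N(c2ccc(S(N)(=O)=O)cc2)C2=C(C(=O)CCC2)C1c1ccc(Cl)cc1Cl` gives 40 ug/mL.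

Compound 2 holds the lowest of the two numbers; the nearest is compound 3, and the step of a 1.6-fold higher number from compound 2 to compound 3 (0.20 log units; within the scatter) lies within the scatter. Compound 4 `N#CC1=C(NS(=O)(=O)c2ccc([N+](=O)[O-])cc2)N(c2ccc(S(N)(=O)=O)cc2)C2=C(C(=O)CCC2)C1c1ccc(Cl)cc1Cl` differs from compound 2 by a group of 12 heavy atoms (6 carbon, 1 nitrogen, 4 oxygen, 1 sulfur; one six-membered aromatic ring of carbon only) in place of a group of 9 heavy atoms (7 carbon, 1 nitrogen, 1 sulfur; one six-membered aromatic ring of carbon only), on an amine nitrogen. The measured steps on that nitrogen are an at least 4.0-fold lower number from compound 1 to compound 2 (0.60 log units; beyond the scatter) and an at least 2.5-fold lower number from compound 1 to compound 3 (0.39 log units; beyond the scatter); one of these starts from a limit, and none exchanges a phenyl for a (4-nitrophenyl)sulfonyl group, so they bear on it only loosely. An estimated step of a 1.2-fold higher number from compound 2 to compound 4 (0.08 log units; within the scatter), within the scatter, is therefore expected. Compound 4 is expected to give about 30 ug/mL, between 12 ug/mL and 100 ug/mL.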

Compound 4, half-maximal inhibitory concentration: 20 ug/mL
Beside the measured number, compound 4's estimate is 1.5-fold (0.18 log units) above it, and the stated range covers the measured number.
By their numbers in this assay, from the lowest: compounds 4, 2 and 3 (each within the scatter of the next). At a limit, above all of these: compound 1.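

On this amine nitrogen, a sulfonyl-linked group does no differently from the earlier aromatic groups: a 1.3-fold lower number from compound 2 to compound 4 (0.10 log units; within the scatter) and a 2.0-fold lower number from compound 3 to compound 4 (0.30 log units; within the scatter) in this assay, so the (4-nitrophenyl)sulfonyl group cannot be told apart from them. All three ring-bearing groups now stand apart from the butyl chain, with an at least 5.0-fold lower number from compound 1 to compound 4 (0.69 log units; beyond the scatter). That step starts from compound 1, which gives only a limit: the limit of > 100 ug/mL in this assay, at which 1 of the 4 values shown sits.

For the compounds shown here, with only one group lacking a ring, it remains open whether the ring itself matters. On these data alone, how a benzyl group, a shorter chain such as methyl, or a carboxylic acid on the ring would fare also stays unknown.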